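This account rests on a few compounds, and the source may have more. Where it says the series, first, only, none or still open, it means among the compounds named here.

Compound 3 `O=C1C(N2CCCC2)=CC(=O)c2c1nc1n2[C@H]2OC[C@@H](O)[C@H]2OC1` carries a pyrrolidin-1-yl group on the shared core. In a functional assay on MCF7 cells (Homo sapiens) for inhibition, read by sulforhodamine B assay (a higher number here means a weaker inhibitor, a lower number a stronger inhibitor), compound 3 gives > 16000 nM, which is a limit of the assay rather than a number. Of the three values known, compound 3 is the one that sits at the limit of > 16000 nM in this assay, at which 1 of the 3 values shown sits. Compound 1 `COc1ccc(NC2=CC(=O)c3c(nc4n3[C@H]3OC[C@@H](O)[C@H]3OC4)C2=O)cc1` gives 4470 nM in this assay. Compound 2 `Cc1ccc(NC2=CC(=O)c3c(nc4n3[C@H]3OC[C@@H](O)[C@H]3OC4)C2=O)cc1` gives > 4000 nM in this assay, which is again a limit and not a number; this is the value at the limit of > 4000 nM in this assay, at which 1 of the 3 values shown sits. Going by the values given here, the one readable step is an at least 3.5-fold higher number from compound 1 to compound 3 (0.55 log units; beyond the scatter), so putting pyrrolidin-1-yl in place of (4-methoxyphenyl)amino gave a higher number. The other two steps, a step that the limit leaves unreadable from compound 1 to compound 2 and a step that the two limits leave unreadable from compound 2 to compound 3, cannot be sized. Compound 4 `CCCN(CCC)C1=CC(=O)c2c(nc3n2[C@H]2OC[C@@H](O)[C@H]2OC3)C1=O` differs from compound 3 by dipropylamino in place of pyrrolidin-1-yl on a double-bonded ring carbon. Among the compounds with values here, no measured step exchanges one such amine for another, so the known steps show only that compound 3 already sits at a limit and that the amine-bearing compounds are weak inhibitors here. For compound 4 the expected step is a step that the limit leaves unreadable from compound 3 to compound 4, that is none beyond the scatter. Compound 4 is estimated at 20000 nM, within a range from 8000 nM to 60000 nM, with a good chance that only a limit is again reported.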

Compound 4, half-maximal inhibitory concentration: > 16000 nM
Compound 4: a limit, no number; the forecaster's own chance of this, stated with the estimate: 70%; the middle value is on the limit's open side.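

Compound 4 is the only compound shown with an open-chain amine on this double-bonded ring carbon, and in this assay compound 4 gives a limit rather than a number, the same limit as compound 3: the limit of > 16000 nM in this assay, at which 2 of the 4 values shown sit. Putting dipropylamino in place of (4-methoxyphenyl)amino gives an at least 3.5-fold higher number from compound 1 to compound 4 (0.55 log units; beyond the scatter), so the loss seen with pyrrolidin-1-yl is no longer tied to that one ring amine and also appears with an amine that has no ring. The steps to compound 4 from compound 2 and from compound 3 cannot be read, so these limits do not rank dipropylamino against pyrrolidin-1-yl or against (4-methylphenyl)amino.

From the compounds shown here alone, how weak compound 3 and compound 4 really are remains open, since neither has a readable number. Also open, going by these compounds, is whether a smaller open-chain amine such as dimethylamino, or a ring amine with a second hetero atom such as morpholin-4-yl, would give a readable value at this position and so allow one amine to be compared directly with another.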